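Aromatase series: cyanomethyl to isopropyl at the alkene carbon

The source may report more compounds than this note shows. Statements on the series, on what has been measured and on what is new or still open speak of the compounds shown alone.

Measured compounds:
- compound 1 `NCCOc1ccc(/C(=C(\CCCl)c2ccccc2)c2ccc(O)cc2)cc1`: 143 nM
- compound 2 `N#CC/C(=C(/c1ccc(O)cc1)c1ccc(OCCN)cc1)c1ccccc1`: 48.9 nM

Both measured compounds share one core and differ only in the group on the saturated chain carbon bound to the double-bonded chain carbon. In an assay on isolated protein for inhibition of Aromatase (Homo sapiens), read by fluorescence, with a stated time of 30 min (on this read-out lower numbers stand for stronger inhibition and higher numbers for weaker inhibition), compound 1 gives 143 nM and compound 2 gives 48.9 nM; the change of a 2.9-fold lower number from compound 1 to compound 2 (0.47 log units; beyond the scatter) is a modest gain. Compound 2 therefore stands with the lowest of the two numbers, and its nearest neighbour is compound 1.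

Compound 3 `CC(C)/C(=C(/c1ccc(O)cc1)c1ccc(OCCN)cc1)c1ccccc1` has not yet been measured. It differs from compound 2 by isopropyl in place of cyanomethyl on a double-bonded chain carbon bound to an aromatic carbon and a double-bonded chain carbon. For the measured compounds named here, the only measured step, a 2.9-fold lower number from compound 1 to compound 2 (0.47 log units; beyond the scatter), concerns the same chain but the opposite exchange in kind: there the nitrile entered and the number fell. Going by the values given here, removing the nitrile again, and leaving a plain hydrocarbon chain as in compound 1, gives no direct precedent, so the expectation leans on compound 1 as the nearest analogue with a nitrile-free chain. Compound 3 is therefore expected to give 120 nM in this assay, within 40 nM to 360 nM, which means an estimated step of a 2.5-fold higher number from compound 2 to compound 3 (0.39 log units; beyond the scatter), that is a modest loss rather than none beyond the scatter.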

Compound 3, half-maximal inhibitory concentration: 328 nM
Compound 3: middle estimate off by 2.7-fold (0.44 log units), on the low side; low and high end bracket the measured number.
By their numbers in this assay, from the lowest: compound 2; then compound 1; then compound 3.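

In this assay, the double-bonded chain carbon bound to an aromatic carbon and a double-bonded chain carbon proves sensitive to the identity of its group, not only to its size: isopropyl in place of cyanomethyl, with 3 heavy atoms leaving and 3 entering, gives a 6.7-fold higher number from compound 2 to compound 3 (0.83 log units; beyond the scatter) and removes the lowest number in the set. Isopropyl in place of 2-chloroethyl gives a 2.3-fold higher number from compound 1 to compound 3 (0.36 log units; beyond the scatter), so the two groups without a nitrile also stand apart, and the lack of a nitrile does not by itself fix the number. Among these three compounds, cyanomethyl carries the lowest number, 2-chloroethyl the middle one and isopropyl the highest, but no measurement available here accounts for this order.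

On these data alone, it remains open whether the low number of compound 2 follows the nitrile itself or the whole cyanomethyl group, a question that 2-cyanoethyl at the same carbon would address. Ethyl or cyclopropyl there would show how far isopropyl represents hydrocarbon groups in general, while an amine or a carboxylic acid would extend the comparison to groups of another kind.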